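Loss of a Nitrogen Methyl Group and Its Consequence

The source may report more compounds than this note shows. Statements on the series, on what has been measured and on what is new or still open speak of the compounds shown alone.

The measured compounds are compound 1 `COc1ccc(OC)c(CNC(=O)NS(=O)(=O)c2ccc(Cl)cc2)c1`, compound 2 `COc1ccc(OC)c(CNC(=O)N(C)S(=O)(=O)c2ccc(Cl)cc2)c1` and compound 3 `COc1ccc(F)cc1C(C)NC(=O)N(C)S(=O)(=O)c1ccccc1`. In a functional assay on thoracic aorta (Rattus norvegicus, strain Wistar), with a stated time of 15 min (on this read-out higher numbers stand for an effect only at larger amounts of compound and lower numbers for an effect already at smaller amounts), compound 2 gives 18200 nM and compound 3 gives 10000 nM. Compound 1 reaches only a limit of the assay in this assay, namely > 300000 nM.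

The cores of compound 2 and compound 3 differ, and that difference is not broken down here; their two numbers lie within the usual scatter of each other. From compound 2 to compound 1 the change is hydrogen in place of methyl on an amide-type nitrogen and it brings an at least 16-fold higher number from compound 2 to compound 1 (1.21 log units; beyond the scatter), with compound 1 sitting at the limit of > 300000 nM in this assay, at which 1 of the 3 values shown sits.

Compound 4 `COc1ccc(F)cc1C(C)NC(=O)NS(=O)(=O)c1ccccc1` is not yet measured. It differs from compound 3 by hydrogen in place of methyl on an amide-type nitrogen, the same change at the same kind of place. Compound 4 is expected to show a 30-fold higher number from compound 3 to compound 4 (1.48 log units; beyond the scatter), an expectation that rests on an at least 16-fold higher number from compound 2 to compound 1 (1.21 log units; beyond the scatter). Compound 4 is accordingly estimated at 300000 nM, between 80000 nM and 1200000 nM, with a real chance that this assay again reports only a limit.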

Compound 4, half-maximal effective concentration: > 300000 nM
Compound 4: a limit, no number; the forecaster's own chance of this, stated with the estimate: 70%; the middle value sits exactly at the limit.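

In this assay, hydrogen in place of methyl on the amide-type nitrogen brings an at least 30-fold higher number from compound 3 to compound 4 (1.47 log units; beyond the scatter), so the change goes in the same direction on both cores shown. This does not show that the change has the same size on the two cores, as neither step has a measured end point: the same change on two cores in this assay, an at least 16-fold higher number (1.21 log units; beyond the scatter) from compound 2 to compound 1 and an at least 30-fold higher number (1.47 log units; beyond the scatter) from compound 3 to compound 4; the limit leaves it open whether they differ. Compound 4 and compound 1 share one limit of the assay and no number: the limit of > 300000 nM in this assay, at which 2 of the 4 values shown sit.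

The compounds shown leave open whether an ethyl group or a longer chain on that nitrogen would give numbers like those of compound 2 and compound 3. They also leave open whether the change carries over to a core bearing an amine or a carboxylic acid.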